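Swapping the ketone aryl group in a weakly cytotoxic series

This account rests on a few compounds, and the source may have more. Where it says the series, first, only, none or still open, it means among the compounds named here.

Compound 1 `COc1cc(C(=O)C2Sc3nnc(-c4cc(OC)c(OC)c(OC)c4)n3NC2c2ccco2)cc(OC)c1OC` and compound 2 `COc1cc(-c2nnc3n2NC(c2ccco2)C(C(=O)c2ccc(C(F)(F)F)cc2)S3)cc(OC)c1OC` share one core and differ only in the group attached to the carbonyl carbon. In a functional assay on PC-3 cells (Homo sapiens) for cytotoxicity, read by MTT assay, with a stated time of 48 h (a lower number here means a stronger inhibitor, a higher number a weaker inhibitor), compound 1 gives 52200 nM and compound 2 gives 77500 nM. The step between them, a 1.5-fold higher number from compound 1 to compound 2 (0.17 log units; within the scatter), is too small to count as a real change. Compound 2 therefore stands with only compound 1 beside it, and the two lie within the usual scatter of each other. Compound 3 `COc1cc(-c2nnc3n2NC(c2ccco2)C(C(=O)c2ccco2)S3)cc(OC)c1OC` has not been measured yet. Its difference from compound 2 is furan-2-yl in place of 4-(trifluoromethyl)phenyl on a carbonyl carbon. Going by the values given here, the only measured step at this position, a 1.5-fold higher number from compound 1 to compound 2 (0.17 log units; within the scatter), stayed within the scatter, so a further swap of the aryl group on the carbonyl carbon is expected to bring no step beyond the scatter, a 1.1-fold lower number from compound 2 to compound 3 (0.04 log units; within the scatter). Compound 3 is estimated at 70000 nM, with a range from 25000 nM to 200000 nM.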

Compound 3, half-maximal inhibitory concentration: 58300 nM
For compound 3 the middle estimate is 1.2-fold (0.08 log units) above the measured one; low and high end bracket the measured number.
By their numbers in this assay, from the lowest: compounds 1, 3 and 2 (each within the scatter of the next).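

In this assay replacing 4-(trifluoromethyl)phenyl with furan-2-yl on the carbonyl carbon gives a 1.3-fold lower number from compound 2 to compound 3 (0.12 log units; within the scatter) and replacing 3,4,5-trimethoxyphenyl with furan-2-yl gives a 1.1-fold higher number from compound 1 to compound 3 (0.05 log units; within the scatter) so neither swap counts as a real change. Even a smaller group with a different ring, a five-membered aromatic ring in place of a six-membered aromatic ring in the step from 4-(trifluoromethyl)phenyl, leaves the number within the scatter, and this position has so far tolerated all three aryl groups without any real gain. No supporting data are available to explain this flat result.

Going by these compounds, what remains open is whether a non-aromatic group on the carbonyl carbon, such as an amine or a carboxylic acid, would move the number beyond the scatter. On these data alone, it is also open whether a longer chain in place of the furan-2-yl group on the shared core would do so.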